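Extending the ether chain with an aminoalcohol

The compounds below may be only part of what the source reports. "The series", "measured", "known", "first", "only" and "open" are said of these compounds alone.

Measured so far:
Compound 1, `COc1cc(OC)c2c(=O)cc(-c3ccc(OCCBr)cc3)oc2c1`: 20%
Compound 2, `COc1cc(OC)c2c(=O)cc(-c3ccc(OCCF)cc3)oc2c1`: 21%

In a functional assay (Homo sapiens) for antiproliferative activity, read by resazurin assay, with a stated time of 48 h, tested at 20 uM (on this read-out higher numbers stand for a stronger effect at the one concentration tested and lower numbers for a weaker effect), compound 1 gives 20%, and compound 2 gives 21%. Within the data shown here, the one measured step, a number 1 percentage points higher from compound 1 to compound 2 (within the scatter), therefore shows no effect of swapping one halogen for another. Compound 2 and compound 1 thus sit together, within the scatter of each other, and neither can be called the stronger.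

Compound 3, `COc1cc(OC)c2c(=O)cc(-c3ccc(OCC(O)CN(C)C)cc3)oc2c1`, changes compound 2 far more: 2-(dimethylamino)-1-hydroxyethyl in place of fluoromethyl on a saturated chain carbon bound to an oxygen on an aromatic ring. Among the measured compounds shown here, no measured step covers a change of this kind, since the only step, a number 1 percentage points higher from compound 1 to compound 2 (within the scatter), exchanges one small atom for another and does not tell how a larger group with a hydroxyl and a dimethylamino end behaves here. The expectation therefore rests on the two measured values staying close, and the step is expected to be a number 4 percentage points higher from compound 2 to compound 3 (within the scatter), a modest one, with wide uncertainty. For compound 3 the estimate in this assay is 25%, within a range from 5% to 50%.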

Compound 3, a percentage reported as inhibition, at one concentration (the size of the read-out at that concentration, not a potency): 71%
For compound 3 the middle estimate is 46 percentage points below the measured one; measured number outside the range, above it.
By their numbers in this assay, from the lowest: compounds 1 and 2 (each within the scatter of the next); then compound 3.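

This change opens up a position that the halogen swap left looking flat. In this assay, putting 2-(dimethylamino)-1-hydroxyethyl in place of fluoromethyl brings a number 50 percentage points higher from compound 2 to compound 3 (beyond the scatter) and the same group in place of bromomethyl brings a number 51 percentage points higher from compound 1 to compound 3 (beyond the scatter) on the same shared core. The read-out at this saturated chain carbon therefore depends strongly on what the chain carries, and the two halogens showed only a small part of that range.

The hydroxyl and the dimethylamino end enter together, so these compounds cannot show which of them matters, or whether both do; a chain ending in the amine alone, a piperidine in place of the dimethylamino end, or a longer chain would each test a different part of the change. Nothing measured here says why the number changes so much.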